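The source may hold more compounds than are shown below. What is called first, only, known or untested is meant among the compounds shown, and "the series" means these compounds.

Working notes on the series, taking the step from compound 3 to compound 4.

Three members have been measured in a functional assay on BXPC-3 cells (Homo sapiens) for inhibition, read by MTT assay, with a stated time of 7 days; a higher number here means a weaker inhibitor, a lower number a stronger inhibitor. Compound 1 `CCN(CC)S(=O)(=O)c1ccc(S(=O)(=O)N2CCC[C@@H](C(=O)N[C@H]3CC[C@H](OC)CC3)C2)cc1` gives 2000 nM. Compound 2 `CCN(CC)S(=O)(=O)c1ccc(S(=O)(=O)N2CCC[C@@H](C(=O)N3CCC(O)CC3)C2)cc1` gives 4710 nM. Compound 3 `CCN(CC)S(=O)(=O)c1ccc(S(=O)(=O)N2CCC[C@@H](C(=O)N3CCC(F)(F)CC3)C2)cc1` gives 120 nM, the lowest of the three numbers, with a 17-fold lower number from compound 1 to compound 3 (1.22 log units; beyond the scatter) and a 39-fold lower number from compound 2 to compound 3 (1.59 log units; beyond the scatter); the gap between the other two is a 2.4-fold higher number from compound 1 to compound 2 (0.37 log units; beyond the scatter).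

Compound 4 `CCN(CC)S(=O)(=O)c1ccc(S(=O)(=O)N2CCC[C@@H](C(=O)N[C@@H]3CCOC3)C2)cc1` is not yet measured. Its change from compound 3 is (oxolan-3-yl)amino in place of 4,4-difluoropiperidin-1-yl on a carbonyl carbon. Within the data shown here, no measured step reproduces this exactly. The nearest guide is the step from compound 1 to compound 3, where an oxygen-bearing secondary amide gave way to the 4,4-difluoropiperidin-1-yl group and the number fell by a 17-fold lower number from compound 1 to compound 3 (1.22 log units; beyond the scatter); compound 4 reverses that type of change, returning to a secondary amide with an oxygen in the ring, now a smaller one. The step from compound 2 to compound 3, a 39-fold lower number from compound 2 to compound 3 (1.59 log units; beyond the scatter), points the same way. From the compounds shown here alone, both oxygen-bearing analogues sit far above compound 3, so a large rise in this assay is expected, with the size uncertain because the oxolan-3-yl group itself is untested.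

The expected step is a 21-fold higher number from compound 3 to compound 4 (1.32 log units; beyond the scatter). Compound 4 is estimated at 2500 nM, in a range from 700 nM to 9000 nM.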

Compound 4, half-maximal inhibitory concentration: 2270 nM
Beside the measured number, compound 4's estimate is 1.1-fold (0.04 log units) above it; low and high end bracket the measured number.
By their numbers in this assay, from the lowest: compound 3; then compounds 1 and 4 (each within the scatter of the next); then compound 2.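

In this assay the step of a 19-fold higher number from compound 3 to compound 4 (1.28 log units; beyond the scatter) shows that the large gap to the 4,4-difluoropiperidin-1-yl group also holds for a third oxygen-bearing group on the carbonyl carbon, and none of the compounds shown goes against this. The step of a 1.1-fold higher number from compound 1 to compound 4 (0.05 log units; within the scatter) shows that oxolan-3-yl and 4-methoxycyclohexyl on the amide-type nitrogen are not separated here, even though the first has a five-membered ring and fewer heavy atoms than the group it is compared with. The step of a 2.1-fold lower number from compound 2 to compound 4 (0.32 log units; beyond the scatter) is a modest change and is small beside the step from compound 3, so the three oxygen-bearing compounds lie much closer to one another than to compound 3.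

The compounds shown leave open whether the two fluorine atoms or the ring nitrogen bonded directly to the carbonyl carbon matters more, a question that an unsubstituted piperidin-1-yl group or a 3,3-difluoropyrrolidin-1-yl group would address. Nothing available explains these steps.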